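Replacing the acylhydrazide tail with a phenylhydrazone

This account rests on a few compounds, and the source may have more. Where it says the series, first, only, none or still open, it means among the compounds named here.

Compound 1 `N#CCC(=O)N/N=C1\C(=O)Nc2ccc(S(=O)(=O)N3CCOCC3)cc21` carries a morpholine sulfonamide on a shared core and a hydrazone tail. In a functional assay on HepG2 cells (Homo sapiens) for cytotoxicity, read by sulforhodamine B assay, with a stated time of 24 h (a higher number here means a weaker inhibitor, a lower number a stronger inhibitor), compound 1 gives 7530 nM, the lowest of the two numbers at hand. For the measured compounds named here, its only neighbour is compound 2 `O=C1Nc2ccc(S(=O)(=O)N3CCOCC3)cc2/C1=N/c1ccc(O)cc1`, which in this assay gives 10400 nM; the step of a 1.4-fold higher number from compound 1 to compound 2 (0.14 log units; within the scatter) stays within the scatter even though it exchanges the whole group on the double-bonded nitrogen. Compound 3 `O=C1Nc2ccc(S(=O)(=O)N3CCOCC3)cc2/C1=N/Nc1ccccc1` is not yet measured. It differs from compound 1 by phenyl in place of (cyanomethyl)carbonyl on an amine nitrogen. Going by the values given here, only the step from compound 1 to compound 2 bears on this change, since it also reworks the tail, and it was small. He therefore expects compound 3 to show a step of about a 1.1-fold higher number from compound 1 to compound 3 (0.05 log units; within the scatter), none beyond the scatter, and estimates for compound 3 a value of 8500 nM, in the range 3000 nM to 25000 nM.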

Compound 3, half-maximal inhibitory concentration: 15600 nM
For compound 3 the middle estimate is 1.8-fold (0.26 log units) below the measured one; the measured number falls inside the stated range.
By their numbers in this assay, from the lowest: compounds 1, 2 and 3 (each within the scatter of the next, the first and the last beyond it).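

In this assay, for the compounds shown here, phenyl in place of (cyanomethyl)carbonyl on the amine nitrogen gives a 2.1-fold higher number from compound 1 to compound 3 (0.32 log units; beyond the scatter) and so provides the first step in this small set to pass beyond the scatter, though only modestly. The anilino group in place of 4-hydroxyphenyl on the double-bonded nitrogen gives a 1.5-fold higher number from compound 2 to compound 3 (0.18 log units; within the scatter) and does not separate these two tails. No measurement offered here explains the step from the acyl tail to the phenyl tail.

The compounds shown do not tell whether the step belongs to phenyl itself or would also appear with a benzyl group, a pyridine ring or a simple acetyl group on that amine nitrogen. With morpholine on the sulfonamide throughout, they also leave open whether the step would persist with piperidine or an open-chain amine there.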